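A few compounds are considered here, and "the series" means these few. Any claim that something is new, unique, unknown or untested is made for them only; others in the source may bear on it.

Compound 2 `COc1ccc(C(=O)/C=C/c2cc(-c3cc(OC)c(OC)c(OC)c3)n[nH]2)cc1OC` belongs to a small set of chalcone-like compounds built on a shared core. In a functional assay on MDA-MB-435 cells (Homo sapiens) for cytotoxicity, read by sulforhodamine B assay, with a stated time of 48 h, tested at 0.1 uM (on this read-out higher numbers stand for a weaker effect at the one concentration tested and lower numbers for a stronger effect), compound 2 gives 92%. Going by the values given here, its only measured neighbour is compound 1 `COc1cc(-c2cc(/C=C/C(=O)c3ccc(Cl)c(Cl)c3)[nH]n2)cc(OC)c1OC`, which in this assay gives 96%; the two numbers sit within the usual scatter of each other, so neither can be called stronger or weaker. Among the compounds with values here, the one measured step, a number 4 percentage points lower from compound 1 to compound 2 (within the scatter), came from putting 3,4-dimethoxyphenyl in place of 3,4-dichlorophenyl on the carbonyl carbon, and it changed nothing beyond the scatter.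

Compound 3 `COc1ccc(C(=O)/C=C/c2cc(-c3cc(OC)c(OC)c(OC)c3)n[nH]2)cc1` has not yet been measured. It differs from compound 2 by a single change: hydrogen in place of methoxy on an aromatic carbon. This removal of one methoxy group touches the same aryl ring whose exchange in the step from compound 1 to compound 2 left the read-out essentially flat. Within the data shown here, with that step as the only guide, no movement beyond the scatter is expected, a number 1 percentage points higher from compound 2 to compound 3 (within the scatter). Compound 3 is therefore estimated to give 93% in this assay, with a likely range from 84% to 100%.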

Compound 3, a percentage reported as activity, at one concentration (the size of the read-out at that concentration, not a potency): 95%
For compound 3 the middle estimate is 2 percentage points below the measured one, within the range that was stated.
By their numbers in this assay, from the lowest: compounds 2, 3 and 1 (each within the scatter of the next).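

In this assay, cutting 3,4-dimethoxyphenyl back to 4-methoxyphenyl gives a number 3 percentage points higher from compound 2 to compound 3 (within the scatter) and so shows that the methoxy group on this aromatic carbon, ortho to a methoxy group, can be replaced by hydrogen with no change that stands out from the usual scatter. The second new comparison, a number 1 percentage points lower from compound 1 to compound 3 (within the scatter) for 4-methoxyphenyl in place of 3,4-dichlorophenyl on the carbonyl carbon, adds a third group at this end of the molecule, and with three groups now compared, none can be ranked above another at this single concentration. No measurement bearing on this flat result is available to explain it.

As far as these compounds go, it remains open whether any other group on this ring, such as an amine or a carboxylic acid, would move the read-out beyond the scatter. From the compounds shown here alone, it is also open whether these three compounds would still be indistinguishable at a higher concentration, since a single concentration shows only the size of the effect there and gives no potency.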